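The source may hold more compounds than are shown below. What is called first, only, known or untested is meant among the compounds shown, and "the series" means these compounds.

Of the compounds shown here, two that share one core have been tested in a functional assay on PC-3 cells (Homo sapiens) for inhibition; on this read-out higher numbers stand for weaker inhibition and lower numbers for stronger inhibition. Compound 1 `COc1cc2nc(N3CCN(S(=O)(=O)c4ccc(Cl)cc4)CC3)nc(N)c2cc1OC` gives 23000 nM, and compound 2 `COc1cc2nc(N3CCN(S(=O)(=O)c4ccc(C)cc4)CC3)nc(N)c2cc1OC` gives 30000 nM. For the measured compounds named here, the single structural change between them produces a 1.3-fold higher number from compound 1 to compound 2 (0.12 log units; within the scatter), so compound 2 stands alongside compound 1 rather than apart from it, and both numbers sit in the weak range of this assay.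

Compound 3 `COc1cc2nc(N3CCN(S(=O)(=O)c4ccc(OC(F)(F)F)cc4)CC3)nc(N)c2cc1OC` has not yet been measured. It differs from compound 2 by trifluoromethoxy in place of methyl on an aromatic carbon. Going by the values given here, the only measured step that bears on this change is the one between compound 1 and compound 2, which also swapped one small group on an aromatic carbon and stayed within the scatter. On that basis the step in this assay is expected to be small, a 1.2-fold lower number from compound 2 to compound 3 (0.08 log units; within the scatter). Compound 3 is therefore estimated at 25000 nM, within a range from 10000 nM to 60000 nM.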

Compound 3, half-maximal inhibitory concentration: 25000 nM
For compound 3 middle estimate and measured number coincide at the digits printed, and the stated range covers the measured number.
By their numbers in this assay, from the lowest: compounds 1, 3 and 2 (each within the scatter of the next).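

Trifluoromethoxy carries more heavy atoms than methyl and adds a hydrogen-bond acceptor, yet on the aromatic carbon para to a large group it gives a 1.2-fold lower number from compound 2 to compound 3 (0.08 log units; within the scatter) in this assay. Against chloro, it gives a 1.1-fold higher number from compound 1 to compound 3 (0.04 log units; within the scatter), so three different groups at this position now give numbers that this read-out cannot tell apart. No measurement is available to explain why these changes leave the number within the scatter.

As far as these compounds go, it remains open whether any group at this position can move the number beyond the scatter, for instance an amine or a carboxylic acid. The compounds shown also leave open whether changes elsewhere, such as replacing the two methoxy groups on the shared core with longer chains, would matter more than this one.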